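The source may report more compounds than this note shows. Statements on the series, on what has been measured and on what is new or still open speak of the compounds shown alone.

Measured set in a functional assay on DU-145 cells (Homo sapiens) for antiproliferative activity, read by MTT assay, with a stated time of 24 h; on this read-out lower numbers stand for stronger inhibition and higher numbers for weaker inhibition:
- compound 1 `COc1cc(-c2cc(C(=O)/C=C/c3ccc(Cl)cc3)nc3cc(-c4ccccc4)nn23)cc(OC)c1OC`: 19500 nM
- compound 2 `COc1ccc(-c2cc(C(=O)/C=C/c3ccc(Cl)cc3)nc3cc(-c4ccccc4)nn23)cc1OC`: 22400 nM
- compound 3 `COc1ccc(-c2cc(/C=C/C(=O)c3ccccc3)nc3cc(-c4ccccc4)nn23)cc1`: 13700 nM

Compound 1 stands second highest of the three numbers; compound 2 sits nearest, and the gap from compound 1 to compound 3 is within the scatter, so the three read as one cluster.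

Compound 4 `COc1ccc(/C=C/C(=O)c2cc(-c3cc(OC)c(OC)c(OC)c3)n3nc(-c4ccccc4)cc3n2)cc1` is not yet measured. Relative to compound 1 the change is methoxy in place of chloro on an aromatic carbon.

For the measured compounds named here, no measured step touches the same carbon. Going by the values given here, the only single-point step on record is a 1.1-fold higher number from compound 1 to compound 2 (0.06 log units; within the scatter), which concerns a methoxy on a different aromatic carbon and stayed within the scatter; compound 3 carries a methoxy rather than a chloro but differs from compound 1 in more than one place, so its value cannot be read as a step. With chloro-to-methoxy exchanges at this site unexplored, the expectation for compound 4 is a step of a 1.0-fold higher number from compound 1 to compound 4 (0.01 log units; within the scatter), that is, nothing clearly beyond the scatter in either direction. Compound 4 is therefore estimated at 20000 nM, with a range from 8000 nM to 50000 nM.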

Compound 4, half-maximal inhibitory concentration: 16900 nM
Estimate against measurement, compound 4: 1.2-fold (0.07 log units) above; the measured number falls inside the stated range.
By their numbers in this assay, from the lowest: compounds 3, 4, 1 and 2 (each within the scatter of the next).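

In this assay, for the compounds shown here, the exchange of 4-chlorophenyl for 4-methoxyphenyl gives the first direct reading at this aromatic carbon, with a 1.2-fold lower number from compound 1 to compound 4 (0.06 log units; within the scatter) as the step, whereas the earlier single-point step concerned a different aromatic carbon. Methoxy brings one more heavy atom and one hydrogen-bond acceptor by count, yet compound 4 cannot be separated from compound 1, so these two groups read alike at this position in this cell assay. No supporting data bear on why the exchange leaves the read-out within the scatter.

As far as these compounds go, whether this flat response extends beyond chloro and methoxy remains open, and an amine, a carboxylic acid or a longer alkoxy chain on the same carbon would test that. From the compounds shown here alone, it is also open whether the same exchange would read alike on the core of compound 2.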